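Widening the naphthalen-1-yl group's replacement: a pyridine test

The compounds below may be only part of what the source reports. "The series", "measured", "known", "first", "only" and "open" are said of these compounds alone.

Measured in a functional assay on SMMC-7721 cells (Homo sapiens) for antiproliferative activity, read by MTT assay, with a stated time of 48 h; a higher number here means a weaker inhibitor, a lower number a stronger inhibitor:
compound 1 `Cn1cc(C2=C(c3nn(CCCN4CCCCC4)c4ncccc34)C(=O)N(c3ccccc3)C2=O)c2ccccc21`: 3050 nM
compound 2 `Cn1cc(C2=C(c3nn(CCCN4CCCCC4)c4ncccc34)C(=O)N(c3cccc4ccccc34)C2=O)c2ccccc21`: 220 nM

Compound 2 has the lower of these two numbers, so it is the stronger inhibitor of the pair. Compound 3 `Cn1cc(C2=C(c3nn(CCCN4CCCCC4)c4ncccc34)C(=O)N(c3ccccn3)C2=O)c2ccccc21` changes one group of compound 2: pyridin-2-yl in place of naphthalen-1-yl on an amide-type nitrogen in a ring. In words, pyridin-2-yl stands in place of naphthalen-1-yl on an amide-type nitrogen in a ring.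

Within the data shown here, one measured step bears on this change: a 14-fold lower number from compound 1 to compound 2 (1.14 log units; beyond the scatter), a large step with naphthalen-1-yl in place of phenyl. Pyridin-2-yl, like phenyl, is a single six-membered aromatic ring, so much of that step may be lost. Among the measured compounds shown here, no measured compound shows the effect of the ring nitrogen alone. A large step to a higher number is therefore expected in this assay. The estimated step is a 10-fold higher number from compound 2 to compound 3 (1.00 log units; beyond the scatter). For compound 3 the expected value is 2200 nM, with an estimated range of 700 nM to 6500 nM.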

Compound 3, half-maximal inhibitory concentration: > 100000 nM
Compound 3: only a limit was reported; the forecaster's own chance of this, stated with the estimate: 4%; at least 45-fold (1.65 log units) between middle value and limit.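

The reading for compound 3 in this assay is a limit and not a number: the limit of > 100000 nM in this assay, at which 1 of the 3 values shown sits. Replacing naphthalen-1-yl with pyridin-2-yl gives an at least 450-fold higher number from compound 2 to compound 3 (2.65 log units; beyond the scatter), and replacing phenyl with pyridin-2-yl gives an at least 32-fold higher number from compound 1 to compound 3 (1.51 log units; beyond the scatter). The earlier pair compared one carbon-only aromatic ring with two, whereas this result shows that the number of rings on the amide-type nitrogen does not settle the outcome: a single ring with one nitrogen in it differs sharply from a single ring of carbon only.

On these data alone, what remains open is whether the outcome depends on where the nitrogen sits in the ring, which a pyridin-3-yl or pyridin-4-yl group would test. As far as these compounds go, it is also open whether a quinolin-4-yl group, with two rings and one nitrogen, would follow compound 2 or compound 3.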